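Bromo for hydrogen on two related cores

The source may hold more compounds than are shown below. What is called first, only, known or untested is meant among the compounds shown, and "the series" means these compounds.

Measured so far, in a functional assay on MDA-MB-231 cells (Homo sapiens) for antiproliferative activity, read by sulforhodamine B assay, with a stated time of 48 h; a higher number here means a weaker inhibitor, a lower number a stronger inhibitor:
compound 1 `COc1ccc2nc(-c3ccc(N/C=C\C(=O)c4cc(OC)c(OC)c(OC)c4)c(C)c3)sc2c1` gives 17000 nM
compound 2 `COc1cc(OC)c2sc(-c3ccc(N/C=C\C(=O)c4cc(OC)c(OC)c(OC)c4)cc3)nc2c1` gives 15800 nM
compound 3 `COc1ccc2nc(-c3ccc(N/C=C\C(=O)c4cc(OC)c(OC)c(OC)c4Br)c(C)c3)sc2c1` gives 9400 nM

Compound 3 differs from compound 1 in one place only, (bromo in place of hydrogen on an aromatic carbon). This change gave a 1.8-fold lower number from compound 1 to compound 3 (0.26 log units; within the scatter), so the two numbers lie within the scatter of each other and the pair establishes no change in potency. Compound 2 carries a different core from compound 1; the difference between the two cores is not broken down here. Compound 2 and compound 1 give numbers within the scatter of each other.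

Compound 4 `COc1cc(OC)c2sc(-c3ccc(N/C=C\C(=O)c4cc(OC)c(OC)c(OC)c4Br)cc3)nc2c1` is not yet measured. It stands to compound 2 as compound 3 stands to compound 1: bromo in place of hydrogen on an aromatic carbon, the same change at the same place. Among the measured compounds shown here, because the one measured instance of this change gave a 1.8-fold lower number from compound 1 to compound 3 (0.26 log units; within the scatter), the expected step on the second core is of a similar, small size. The expected step is a 1.7-fold lower number from compound 2 to compound 4 (0.22 log units; within the scatter). Compound 4 is therefore estimated at 9500 nM in this assay, with a range from 5000 nM to 18000 nM that reflects a single precedent lying itself within the scatter.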

Compound 4, half-maximal inhibitory concentration: 16100 nM
Estimate against measurement, compound 4: 1.7-fold (0.23 log units) below; low and high end bracket the measured number.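

On the second core, bromo in place of hydrogen on an aromatic carbon gave a 1.0-fold higher number from compound 2 to compound 4 (0.01 log units; within the scatter) in this assay, so this pair, like the first, establishes no change in potency. Set side by side, the steps on the two cores do not differ: the same change on two cores in this assay, a 1.8-fold lower number (0.26 log units; within the scatter) from compound 1 to compound 3 and a 1.0-fold higher number (0.01 log units; within the scatter) from compound 2 to compound 4, 1.8-fold (0.27 log units) apart, within the scatter of two such steps. This shows that the change behaves alike on the two cores within the resolution of the assay, but with both steps inside the scatter it does not show that bromo has a real effect on either core, nor that any effect would carry over to a further core.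

The compounds shown leave open whether another group at the same place, such as chloro, an amine or a carboxylic acid, would give a step beyond the scatter on either core. Also open, as far as these compounds go, is what a longer chain, such as ethoxy, would do in place of one of the methoxy groups on that ring.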